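Aryl ketone swap on the shared core: compound 1 to compound 4

A few compounds are considered here, and "the series" means these few. Any claim that something is new, unique, unknown or untested is made for them only; others in the source may bear on it.

Compound 1 `C#CCOc1ccc(/C=C/C(=O)c2cccc(Br)c2)cc1OC` is the reference point for the step considered here. In a functional assay on CCRF-CEM cells (Homo sapiens) for cytotoxicity, with a stated time of 72 h (a lower number here means a stronger inhibitor, a higher number a weaker inhibitor), compound 1 gives 15200 nM. Compound 3 `C=CCOc1ccc(C=O)cc1OC`, the aldehyde bearing an allyl ether, gives 14000 nM in this assay; that number lies within the scatter of the value of compound 1, so the two cannot be told apart. Compound 2 `C=CCOc1ccc(/C=C/C(=O)c2ccc(OCC=C(C)C)c(CC=C)c2)cc1OC` gives > 50000 nM in this assay, which is a limit of the assay and not a number, namely (the limit of > 50000 nM in this assay, at which 1 of the 3 values shown sits).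

Compound 4 `C#CCOc1ccc(/C=C/C(=O)c2ccc(C)cc2)cc1OC` has not yet been measured. Relative to compound 1 it differs by 4-methylphenyl in place of 3-bromophenyl on a carbonyl carbon. No pair of measured compounds separates the effect of this swap, so nothing shown gives its direction or size. The two measured numbers, those of compound 1 and compound 3, are close to each other despite different groups at the carbonyl end, which gives no sign that this position moves the value by much. The step of a 1.3-fold higher number from compound 1 to compound 4 (0.12 log units; within the scatter) is therefore expected to stay within the scatter, with a slight lean toward the weaker side. In this assay compound 4 is estimated at 20000 nM, with a range from 8000 nM to 50000 nM.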

Compound 4, half-maximal inhibitory concentration: > 50000 nM
Compound 4 was reported as a limit; the forecaster's own chance of this, stated with the estimate: 25%; at least 2.5-fold (0.39 log units) between middle value and limit.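

Changing the group on a carbonyl carbon from 3-bromophenyl to 4-methylphenyl on the shared core gives, in this assay, an at least 3.2-fold higher number from compound 1 to compound 4 (0.51 log units; beyond the scatter). Among these compounds, this is the first single-change pair, and it shows that the aryl group at this position can move the read-out, which the earlier compounds could not show because none of them differed in one place. Compound 4 gives > 50000 nM, which is a limit of the assay and not a number, and the series now has a second compound at that limit: the limit of > 50000 nM in this assay, at which 2 of the 4 values shown sit.

This one pair changes the ring substituent and its place on the ring together, so it cannot tell whether losing the bromine, gaining the methyl or the shift in substitution accounts for the step. It also leaves open whether any other aryl group on this carbonyl carbon, such as a phenyl ring carrying an amine or a carboxylic acid, would stay near compound 1 at 15200 nM.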